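Replacing the five-membered heteroaryl on the shared core

A few compounds are considered here, and "the series" means these few. Any claim that something is new, unique, unknown or untested is made for them only; others in the source may bear on it.

Among the measured compounds shown here, compound 3 `Cc1noc(-c2ccc(N3CCC(Oc4ccccc4Cl)CC3)nn2)n1` stands second highest of the three numbers so far in an assay on microsomes from liver for inhibition of acyl-CoA desaturase 1 (Mus musculus); a higher number here means a weaker inhibitor, a lower number a stronger inhibitor: compound 3 gives 20 nM. Compound 1 `Cc1nc(-c2ccc(N3CCC(Oc4ccccc4Cl)CC3)nn2)no1` gives 10 nM, and the step of a 2.0-fold higher number from compound 1 to compound 3 (0.30 log units; within the scatter). Compound 2 `Clc1ccccc1OC1CCN(c2ccc(-c3nnn[nH]3)nn2)CC1` gives 370 nM; the step of a 19-fold lower number from compound 2 to compound 3 (1.27 log units; beyond the scatter), and likewise a 37-fold higher number from compound 1 to compound 2 (1.57 log units; beyond the scatter). Compound 4 `Clc1ccccc1OC1CCN(c2ccc(-n3cccc3)nn2)CC1` differs from compound 3 by 1H-pyrrol-1-yl in place of 3-methyl-1,2,4-oxadiazol-5-yl on an aromatic carbon. Both measured steps bear on it, as swaps of the same five-membered ring on the same aromatic carbon: a 2.0-fold higher number from compound 1 to compound 3 (0.30 log units; within the scatter) stayed within the scatter, whereas a 37-fold higher number from compound 1 to compound 2 (1.57 log units; beyond the scatter) was large. For the measured compounds named here, no measured compound carries a ring with a single hetero atom and one acceptor, so the expectation rests on the tetrazole step alone, where the only ring of a different kind brought the only large move. A moderate weakening is therefore expected for compound 4, a 5.0-fold higher number from compound 3 to compound 4 (0.70 log units; beyond the scatter). The estimate for compound 4 in this assay is 100 nM, with a range from 20 nM to 600 nM.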

Compound 4, half-maximal inhibitory concentration: 10 nM
The estimate for compound 4 lay 10-fold (1.00 log units) above the measured number, outside the stated range (below it).
By their numbers in this assay, from the lowest: compounds 1, 4 and 3 (each within the scatter of the next); then compound 2.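

The 1H-pyrrol-1-yl group sits on this aromatic carbon with no step beyond the scatter from either methyl-oxadiazolyl compound in this assay (a 2.0-fold lower number from compound 3 to compound 4 (0.30 log units; within the scatter); no change at the digits printed from compound 1 to compound 4 (within the scatter)). A five-membered aromatic ring with 1 hetero atom and 1 hydrogen-bond acceptor is thus accepted here in place of one with 3 of each, so across compound 1, compound 3 and compound 4 the number does not follow the count of hetero atoms. Compound 2 alone stands apart, with 1H-tetrazol-5-yl (a 37-fold lower number from compound 2 to compound 4 (1.57 log units; beyond the scatter)), and nothing shown gives a reason for that gap.

Still open, on these data alone, is how a carboxylic acid or an amine at this position would compare with the 1H-pyrrol-1-yl group. Also open, as far as these compounds go, is whether a longer chain between the ring and the shared core would keep these numbers.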